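Propylamino for fluoro on the pyridine of a TRPV1 antagonist

The source may report more compounds than this note shows. Statements on the series, on what has been measured and on what is new or still open speak of the compounds shown alone.

Compound 1 `C[C@@H]1CN(c2ncccc2C(F)(F)F)CCN1C(=O)Nc1ccc(C(F)(F)F)cc1` gives 17 nM in a functional assay for antagonist activity at transient receptor potential cation channel subfamily V member 1 (Homo sapiens), read by FLIPR; a higher number here means a weaker inhibitor, a lower number a stronger inhibitor. Compound 2 `Cc1cccnc1-c1ccc(C(=O)Nc2ccc(C(F)(F)F)cc2)cc1` gives 65 nM. Compound 3 `CC(C)(C)c1ccc(NC(=O)c2ccc(-c3ncccc3F)cc2)cc1` gives 3 nM.

Among these three, compound 3 carries the lowest number in this assay; the nearest of the others, compound 1, lies well beyond the scatter, and compound 2 lies further still. The next step leads to compound 4 `CCCNc1cccnc1-c1ccc(C(=O)Nc2ccc(C(C)(C)C)cc2)cc1`, which keeps the core of compound 3 and differs in one place: propylamino in place of fluoro on an aromatic carbon. For the measured compounds named here, no measured pair shows this exchange, so the account of compound 3 gives the only anchor. Compound 4 is expected to remain potent, with a modest loss estimated at a 3.3-fold higher number from compound 3 to compound 4 (0.52 log units; beyond the scatter), giving a value near 10 nM within 2 nM to 60 nM.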

Compound 4, half-maximal inhibitory concentration: 158 nM
For compound 4 the middle estimate is 16-fold (1.20 log units) below the measured one; the measured number lies above the stated range.
By their numbers in this assay, from the lowest: compound 3; then compound 1; then compound 2; then compound 4.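

At this position, ortho to a large group, propylamino in place of fluoro gives a 53-fold higher number from compound 3 to compound 4 (1.72 log units; beyond the scatter) in this assay, so the position that carries fluoro in the low-nanomolar compound 3 does not accept this exchange without a large weakening of inhibition. The step changes size and hydrogen-bond donor count together, and it cannot separate the two. Nothing available bears on the cause of this result. Open, going by these compounds, is whether a shorter amine such as methylamino, or an ether such as methoxy, would keep the potency here.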